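The source may report more compounds than this note shows. Statements on the series, on what has been measured and on what is new or still open speak of the compounds shown alone.

Three compounds have been measured in a functional assay on PC-3 cells (Homo sapiens) for antiproliferative activity, read by MTT assay, with a stated time of 96 h; a lower number here means a stronger inhibitor of growth, a higher number a weaker inhibitor of growth:

compound 1, `Oc1cccc2ccc(Sc3ccccn3)nc12`, gives 20900 nM
compound 2, `Oc1ccc(Cl)c2ccc(Sc3ccccn3)nc12`, gives 10200 nM
compound 3, `COc1cccc2ccc(Nc3ccccn3)nc12`, gives 7470 nM

Compound 1 and compound 2 share a core and differ in one place: chloro in place of hydrogen on an aromatic carbon. This change brought a 2.0-fold lower number from compound 1 to compound 2 (0.31 log units; beyond the scatter). Compound 3 stands on a second core; how it differs from compound 1 is not broken down here, and its value lies within the scatter of compound 2 while it sits clearly under compound 1.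

Compound 4, `COc1ccc(Cl)c2ccc(Nc3ccccn3)nc12`, is not yet measured. It arises from compound 3 by chloro in place of hydrogen on an aromatic carbon. The change is the same kind of change as that from compound 1 to compound 2, though the place is not identical: in compound 2 the chloro sits para to a hydroxy group, in compound 4 para to a methoxy group.

Among the compounds with values here, the expectation for compound 4 rests on compound 1 and compound 2, because a 2.0-fold lower number from compound 1 to compound 2 (0.31 log units; beyond the scatter) is the only measured instance of this change, and the step is expected to be a 1.9-fold lower number from compound 3 to compound 4 (0.27 log units; within the scatter). The estimate for compound 4 in this assay is therefore 4000 nM, with a range from 1500 nM to 10000 nM.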

Compound 4, concentration for 50% growth inhibition: 29200 nM
For compound 4 the middle estimate is 7.3-fold (0.86 log units) below the measured one; measured number above the stated range.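

In this assay the chloro group did not carry its effect from one core to the other: on the core of compound 3 it gave a 3.9-fold higher number from compound 3 to compound 4 (0.59 log units; beyond the scatter), the opposite direction to the step seen on the core of compound 1. The two steps disagree by more than repeat measurements would explain: the same change on two cores in this assay, a 2.0-fold lower number (0.31 log units; beyond the scatter) from compound 1 to compound 2 and a 3.9-fold higher number (0.59 log units; beyond the scatter) from compound 3 to compound 4, 8.0-fold (0.90 log units) apart, beyond the scatter of two such steps This shows that, for these two cores, the step measured on one did not predict the step on the other, but with a single pair on each core it does not show why, nor how the change would behave on any further core.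

The two cores differ in more than one place, so the compounds shown leave open whether the reversal goes with the methoxy group in place of the hydroxy group or with the nitrogen link in place of the sulfur link. They also leave open how a bromo or a methyl group in the place of the chloro would behave on either core.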